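A few compounds are considered here, and "the series" means these few. Any claim that something is new, unique, unknown or untested is made for them only; others in the source may bear on it.

Among the compounds with values here, compound 3 `CCOC(=O)c1oc2ccc(N(Cc3ccccc3)S(=O)(=O)c3ccc(C(F)(F)F)cc3)cc2c1C` gives 12700 nM in a functional assay on HCT-116 cells (Homo sapiens) for inhibition, read by MTT assay, with a stated time of 72 h (a lower number here means a stronger inhibitor, a higher number a weaker inhibitor), the highest of the two numbers known, with compound 1 `CCOC(=O)c1oc2ccc(N(Cc3ccccc3)S(=O)(=O)c3ccc(Br)cc3)cc2c1C` nearest at 8700 nM. Compound 2 `CCOC(=O)c1oc2ccc(N(Cc3ccccc3)S(=O)(=O)c3cccc(Br)c3)cc2c1C` reaches only a limit of this assay, > 40000 nM. Compound 4 `CCOC(=O)c1oc2ccc(N(Cc3ccccc3)S(=O)(=O)c3ccc(Cl)cc3)cc2c1C` differs from compound 3 by chloro in place of trifluoromethyl on an aromatic carbon. The step that bears on this is a 1.5-fold higher number from compound 1 to compound 3 (0.16 log units; within the scatter), where one group replaced another on the aromatic carbon without moving past the scatter. The other two steps, an at least 4.5-fold higher number from compound 1 to compound 2 (0.66 log units; beyond the scatter) and an at least 3.1-fold lower number from compound 2 to compound 3 (0.49 log units; beyond the scatter), change where the group sits rather than what it is. A step of a 1.3-fold lower number from compound 3 to compound 4 (0.13 log units; within the scatter) is therefore expected, not beyond the scatter. Compound 4 is estimated at 9500 nM, between 3500 nM and 28000 nM.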

Compound 4, half-maximal inhibitory concentration: 23200 nM
For compound 4 the middle estimate is 2.4-fold (0.39 log units) below the measured one, and the stated range covers the measured number.
By their numbers in this assay, from the lowest: compounds 1, 3 and 4 (each within the scatter of the next, the first and the last beyond it). At a limit, above all of these: compound 2.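

On this aromatic carbon, the identity of the group can matter: chloro in place of bromo gives a 2.7-fold higher number from compound 1 to compound 4 (0.43 log units; beyond the scatter), whereas the earlier swap of bromo for trifluoromethyl stayed within the scatter. Chloro in place of trifluoromethyl gives a 1.8-fold higher number from compound 3 to compound 4 (0.26 log units; within the scatter), so compound 3 cannot be told apart from either neighbour in this series. Compound 2 sits at a limit, so an at least 1.7-fold lower number from compound 2 to compound 4 (0.23 log units; that floor lies within the scatter) gives only a floor. As far as these compounds go, whether an amine, a carboxylic acid or a methoxy group here would lower the number in this assay stays open.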